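Inverting One Stereocentre of Compound 1

The source may report more compounds than this note shows. Statements on the series, on what has been measured and on what is new or still open speak of the compounds shown alone.

In a physicochemical assay for lipophilicity, at pH 7.4 (a lower number here means a more polar compound, a higher number a more lipophilic compound), compound 1 (`Cc1cc(C)c(CN2CCc3c(Cl)cc([C@H](CO)[C@H]4CCCO4)c(Cl)c3C2=O)c(=O)[nH]1`) gives 2.1 and stands level with compound 2 (`COC(c1cc(Cl)c2c(c1Cl)C(=O)N(Cc1c(C)cc(C)[nH]c1=O)CC2)C1CCS(=O)(=O)CC1`), which gives 2.2; 2.2 (2 entries) in its two entries, while compound 3 (`COC(c1cc(Cl)c2c(c1Cl)C(=O)N(Cc1c(C)cc(C)[nH]c1=O)CC2)C1CCN(C2COC2)CC1`) reads higher at 2.7; 2.8 (2 entries) over its two entries. Compound 4 (`Cc1cc(C)c(CN2CCc3c(Cl)cc([C@@H](CO)[C@H]4CCCO4)c(Cl)c3C2=O)c(=O)[nH]1`) differs from compound 1 by the two compounds have the same atoms and bonds and differ only in configuration as drawn: 1 of 2 stereo elements differ; a stereocentre at a saturated chain carbon is drawn R in compound 1 and S in compound 4 and nothing else: the two compounds have the same atoms and bonds, and a stereocentre at a saturated chain carbon is drawn R in compound 1 and S in compound 4. Among the compounds with values here, no measured pair here shows what such an inversion does, so the expected no change at the digits printed from compound 1 to compound 4 (within the scatter) in this assay is estimated to stay within the scatter, with no direction favoured. The estimate for compound 4 is 2.1 within an expected range of 1.8 to 2.4 for this measurement.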

Compound 4, distribution coefficient: 2.5
The estimate for compound 4 lay 0.40 log units below the measured number; measured number above the stated range.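

In this assay, inverting this saturated chain carbon gives a number 0.40 log units higher from compound 1 to compound 4 (beyond the scatter). The earlier compounds shown here offered no pair differing in one place, and this step shows that the position responds to configuration alone, with no atom or bond changed: the fact that compounds 1 and 4 differ only in the configuration as drawn. Open, as far as these compounds go, is whether inverting this carbon gives a step of this size and direction in any other pair, and whether inverting the second stereo element moves the reading at all. Also open, from the compounds shown here alone, is how an amine or a carboxylic acid at this chain carbon would read in this assay.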